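A few compounds are considered here, and "the series" means these few. Any claim that something is new, unique, unknown or untested is made for them only; others in the source may bear on it.

Of the compounds shown here, two built on one shared core have so far been tested in a functional assay on SMMC-7721 cells (Homo sapiens) for antiproliferative activity, read by MTT assay, with a stated time of 48 h; a lower number here means a stronger inhibitor, a higher number a weaker inhibitor. Compound 1 `COc1cc(OC)c2c(=O)c(OCCCOc3ccccc3/C=C/C(=O)/C=C/c3scnc3C)c(-c3cc(OC)c(OC)c(OC)c3)oc2c1` gives 7210 nM in this assay. Compound 2 `COc1cc(OC)c2c(=O)c(OCCCCOc3ccccc3/C=C/C(=O)/C=C/c3ccco3)c(-c3cc(OC)c(OC)c(OC)c3)oc2c1` gives 8480 nM in this assay, and the two numbers lie within the usual scatter of each other, so neither can be called stronger. Compound 3 `COc1cc(OC)c2c(=O)c(OCCCCOc3ccccc3/C=C/C(=O)/C=C/c3cccc([N+](=O)[O-])c3)c(-c3cc(OC)c(OC)c(OC)c3)oc2c1` differs from compound 2 by 3-nitrophenyl in place of furan-2-yl on a double-bonded chain carbon bound to a double-bonded chain carbon. Going by the values given here, no measured pair shows this change, so its size is unknown. The step expected in this assay, a 1.2-fold lower number from compound 2 to compound 3 (0.08 log units; within the scatter), is none beyond the scatter. Compound 3 is therefore estimated at 7000 nM, with a range from 3000 nM to 16000 nM.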

Compound 3, half-maximal inhibitory concentration: 7310 nM
Estimate against measurement, compound 3: 1.0-fold (0.02 log units) below; low and high end bracket the measured number.
By their numbers in this assay, from the lowest: compounds 1, 3 and 2 (each within the scatter of the next).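

Replacing furan-2-yl with 3-nitrophenyl on a double-bonded chain carbon bound to a double-bonded chain carbon gives, in this assay, a 1.2-fold lower number from compound 2 to compound 3 (0.06 log units; within the scatter) for a swap from 5 to 9 heavy atoms. In this one pair, a five-membered aromatic ring and a nitro-bearing six-membered carbon ring therefore read alike at this place. Nothing measured here explains that result.

Still open, on these data alone, is whether a plain phenyl, or a phenyl carrying an amine or a carboxylic acid, would move the number beyond the scatter.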